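The source may report more compounds than this note shows. Statements on the series, on what has been measured and on what is new or still open speak of the compounds shown alone.

In a functional assay on LoVo cells (Homo sapiens) for inhibition, read by MTT assay, with a stated time of 24 h (on this read-out lower numbers stand for stronger inhibition and higher numbers for weaker inhibition), compound 1 `CC1(C)[C@H]2CC[C@]1(C)N(Cc1cn(-c3ccccc3Br)nn1)C(=O)C2` gives 60 nM while compound 2 `CC1(C)[C@H]2CC[C@]1(C)N(Cc1cn(-c3cccc(Cl)c3)nn1)C(=O)C2` gives 70 nM and compound 3 `COc1ccccc1-n1cc(CN2C(=O)C[C@@H]3CC[C@@]2(C)C3(C)C)nn1` gives 70 nM as its reading. Compound 3 therefore stands level with compound 2 and within the scatter of compound 1. Compound 4 `Cc1ccc(-n2cc(CN3C(=O)C[C@@H]4CC[C@@]3(C)C4(C)C)nn2)cc1` keeps the shared core but has 4-methylphenyl in place of 2-methoxyphenyl on an aromatic nitrogen, a swap counted as 4-methylphenyl in place of 2-methoxyphenyl on an aromatic nitrogen and placed where the other compounds also vary. The measured steps that bear on it are changes of the group at that same place, namely a 1.2-fold higher number from compound 1 to compound 2 (0.07 log units; within the scatter) and a 1.2-fold higher number from compound 1 to compound 3 (0.07 log units; within the scatter) and also no change at the digits printed from compound 2 to compound 3 (within the scatter) and all of them lie within the scatter. None of these compounds carries 4-methylphenyl, so that group remains untested. No step beyond the scatter is therefore expected in this assay for this swap. The expected change is no change at the digits printed from compound 3 to compound 4 (within the scatter) in size. Compound 4 is thus estimated at 70 nM within an expected range of 30 nM to 160 nM once it is measured.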

Compound 4, half-maximal inhibitory concentration: 50 nM
Compound 4: the middle estimate sits 1.4-fold (0.15 log units) above what was measured; the measured number falls inside the stated range.
By their numbers in this assay, from the lowest: compounds 4, 1, 2 and 3 (each within the scatter of the next).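

In this assay, the change to 4-methylphenyl gives a 1.4-fold lower number from compound 3 to compound 4 (0.15 log units; within the scatter) and a 1.4-fold lower number from compound 2 to compound 4 (0.15 log units; within the scatter) and a 1.2-fold lower number from compound 1 to compound 4 (0.08 log units; within the scatter) as well. Among these compounds, the position now holds a phenyl group with a substituent of carbon only, without the hydrogen-bond acceptor counted in 2-methoxyphenyl, and still no step leaves the scatter, so 2-bromophenyl, 3-chlorophenyl, 2-methoxyphenyl and 4-methylphenyl read alike on this aromatic nitrogen. No evidence is available to account for these readings.

The compounds shown do not reveal what, if anything, would move the number beyond the scatter at this position. An aminophenyl or carboxyphenyl group, or a straight butyl chain in place of the phenyl ring, might do so, and the four compounds give no indication either way.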